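This account rests on a few compounds, and the source may have more. Where it says the series, first, only, none or still open, it means among the compounds named here.

Series notes. Compound 1 `COc1ccc2nc(SCC(=O)N(Cc3ccc(OC)c(O)c3)c3cc(OC)c(OC)c(OC)c3)sc2c1` gives 352 nM in a functional assay on HCT-116 cells (Homo sapiens) for antiproliferative activity, read by MTT assay, with a stated time of 48 h; a higher number here means a weaker inhibitor, a lower number a stronger inhibitor. Compound 2 `COc1ccc(CN(C(=O)CSc2nc3ccccc3s2)c2cc(OC)c(OC)c(OC)c2)cc1F` gives 1830 nM, the second highest of the three numbers; compound 3 `COc1ccc(CN(C(=O)CSc2nc3cc(Br)ccc3s2)c2cc(OC)c(OC)c(OC)c2)cc1O` gives 3380 nM, within the scatter of compound 2, while compound 1 lies beyond the scatter at the low end. Among the measured compounds shown here, the only single-point step measured, a 9.6-fold higher number from compound 1 to compound 3 (0.98 log units; beyond the scatter), concerns the group on the sulfur and not the benzyl group. Compound 4 `COc1cc(N(Cc2ccc(C)cc2)C(=O)CSc2nc3ccccc3s2)cc(OC)c1OC` differs from compound 2 by 4-methylphenyl in place of 3-fluoro-4-methoxyphenyl on a saturated chain carbon bound to an amide-type nitrogen. For the measured compounds named here, no measured step touches this position; compounds 1 and 2 differ there and at a second place, so their values speak only loosely. A step of a 1.4-fold higher number from compound 2 to compound 4 (0.14 log units; within the scatter) is therefore expected, near the scatter. Compound 4 is estimated at 2500 nM, with a range from 900 nM to 7000 nM.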

Compound 4, half-maximal inhibitory concentration: > 80000 nM
Compound 4 gave a limit, no number (the forecaster's own chance of this, stated with the estimate: 5%); at least 32-fold (1.50 log units) between middle value and limit.
By their numbers in this assay, from the lowest: compound 1; then compounds 2 and 3 (each within the scatter of the next). At a limit, above all of these: compound 4.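

The step on the sulfur said nothing about this position, but the group on the saturated chain carbon bound to an amide-type nitrogen clearly matters: 4-methylphenyl in place of 3-fluoro-4-methoxyphenyl gives an at least 43-fold higher number from compound 2 to compound 4 (1.64 log units; beyond the scatter). Compound 4 gives a limit, > 80000 nM, not a number, so the step is only a minimum: the limit of > 80000 nM in this assay, at which 1 of the 4 values shown sits.

The fluorine and the methoxy leave together here, and the compounds shown do not separate them. Going by these compounds, how an amine or a carboxylic acid on this phenyl ring would read also stays open.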